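The compounds below may be only part of what the source reports. "The series", "measured", "known", "first", "only" and "open" are said of these compounds alone.

Of the compounds shown here, three have been tested in an assay on isolated protein for inhibition of vascular endothelial growth factor receptor 1 (Homo sapiens), read by ELISA, with a stated time of 20 min, tested at 1 uM; on this read-out higher numbers stand for more inhibition at the one concentration tested (going by the name of the read-out) and lower numbers for less inhibition. Compound 1 `COc1cc2ncnc(Nc3cccc(Cl)c3)c2cc1B1OC(C)(C)C(C)(C)O1` is reported in this assay as "not active" (no number reported), and compound 3 `OB(O)c1ccc2ncnc(Nc3cccc(Cl)c3)c2c1` gives 7%. Compound 2 `COCCOc1cc2ncnc(Nc3cccc(B(O)O)c3)c2cc1OCCOC` is reported as "not active" (no number reported), with no single number behind it, so its standing cannot be placed more closely than that, and one further compound shares this outcome. Compound 4 `COCCOc1cc2ncnc(Nc3cccc(B(O)O)c3)c2cc1OC` differs from compound 2 in one place: hydrogen in place of methoxymethyl on a saturated chain carbon bound to an oxygen on an aromatic ring. Within the data shown here, no measured pair shows this change, so there is no step to lean on. Because compound 2 is reported as "not active" (no number reported), the change is expected to move the read-out in this assay by nothing beyond the usual scatter. Compound 4 is therefore estimated at 5%, within a range from 0% to 20%.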

Compound 4, a percentage reported as inhibition, at one concentration (the size of the read-out at that concentration, not a potency): 19%
Compound 4: middle estimate off by 14 percentage points, on the low side; measured number inside the range.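

Among these compounds, compound 2 carries no number in this assay, so no step from it to compound 4 can be read. The compounds shown leave open how far changing 2-methoxyethoxy to methoxy moves this read-out. Nothing measured here offers an explanation for the result of compound 4.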